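Ester chain step from compound 3 to compound 4

The source may report more compounds than this note shows. Statements on the series, on what has been measured and on what is new or still open speak of the compounds shown alone.

Measured in a physicochemical assay for lipophilicity, measured as octanol-water partition, at pH 2; a lower number here means a more polar compound, a higher number a more lipophilic compound:
- compound 1 `CCOC(=O)[C@@H](N)CCC(=O)NCCSC(=O)c1ccccc1`: 1.09
- compound 2 `CCOC(=O)[C@@H](N)CCC(=O)NCCSC(=O)C(C)(C)C`: 1.22
- compound 3 `CCCOC(=O)[C@@H](N)CCC(=O)NCCSC(C)=O`: 0.21

Compound 3 holds the lowest of the three numbers, beyond the scatter from both compound 1 and compound 2. The next structure, compound 4 `CCOC(=O)[C@@H](N)CCC(=O)NCCSC(C)=O`, differs from compound 3 by hydrogen in place of methyl on a saturated chain carbon, two bonds along the chain from an oxygen next to a carbonyl group, which reads as propoxy to ethoxy. For the measured compounds named here, the one measured step, a number 0.13 log units higher from compound 1 to compound 2 (within the scatter), is tert-butyl in place of phenyl on a carbonyl carbon, a different place, so it gives no size for this change. Going by the values given here, no measured step covers the ester chain. The expectation in this assay, resting on the structural change alone, is a number 0.41 log units lower from compound 3 to compound 4 (beyond the scatter). For compound 4 the estimated value is -0.2, with an expected range of -0.5 to 0.15.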

Compound 4, partition coefficient: 0.11
Compound 4: the middle estimate sits 0.31 log units below what was measured; low and high end bracket the measured number.
By their numbers in this assay, from the lowest: compounds 4 and 3 (each within the scatter of the next); then compounds 1 and 2 (each within the scatter of the next).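

In this assay, for the compounds shown here, the single step at this position, propoxy to ethoxy, is a number 0.10 log units lower from compound 3 to compound 4 (within the scatter), so shortening the ester chain here leaves the number within the scatter. Changes to the group on the carbonyl carbon give far larger steps: methyl in place of tert-butyl is a number 1.11 log units lower from compound 2 to compound 4 (beyond the scatter), and methyl in place of phenyl is a number 0.98 log units lower from compound 1 to compound 4 (beyond the scatter).

Going by these compounds, whether a longer chain or a carboxylic acid at the ester position would shift the number beyond the scatter remains open. Nothing measured bears on the reason for these steps.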